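A few compounds are considered here, and "the series" means these few. Any claim that something is new, unique, unknown or untested is made for them only; others in the source may bear on it.

Working notes on the series. Compound 2 `Cc1nc(-c2ccc(Cl)cc2)sc1C(=O)CSc1nc(-c2ccc(Cl)cc2)c(C#N)c(=O)[nH]1` and compound 1 `COc1ccc(-c2nc(SCC(=O)c3sc(-c4ccccc4)nc3C)[nH]c(=O)c2C#N)cc1OC` share a core; compound 2 carries 4-chlorophenyl at both ends, while compound 1 carries phenyl on the thiazole side and a ring bearing two methoxy groups on the other. In a functional assay on U-87MG ATCC cells for antiproliferative activity against U-87 MG (Homo sapiens), read by MTT assay, with a stated time of 48 h, tested at 5 uM (on this read-out lower numbers stand for a stronger effect and higher numbers for a weaker effect at the one concentration tested), compound 2 gives 99%, the highest of the two numbers at hand, and compound 1 gives 80.8%. The gap between compound 2 and compound 1 lies beyond the scatter, so compound 2 shows the weaker effect of the two. Among the measured compounds shown here, no measured pair differs in one place only, so no single step is available yet. Compound 3 `Cc1nc(-c2ccccc2)sc1C(=O)CSc1nc(-c2ccc(Cl)cc2)c(C#N)c(=O)[nH]1` is the next member: hydrogen in place of chloro on an aromatic carbon; the group leaves the aromatic carbon that stands para to a large group, and one bond further out the change reads 4-chlorophenyl to phenyl. Compound 1 also carries phenyl at that end and gives the lower number, but it differs in the second ring as well, so it is no measure of this change. With little to go on, compound 3 is expected to move modestly toward a stronger effect, the expected step being a number 7 percentage points lower from compound 2 to compound 3 (within the scatter). The estimate for compound 3 is 92%, within 78% and 104%.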

Compound 3, a percentage reported as activity, at one concentration (the size of the read-out at that concentration, not a potency): 90.9%
Compound 3: middle estimate off by 1.1 percentage points, on the high side, within the range that was stated.
By their numbers in this assay, from the lowest: compound 1; then compounds 3 and 2 (each within the scatter of the next).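

Working notes, continued. At the aromatic carbon para to a large group, chloro and hydrogen cannot be told apart in this assay (a number 8.1 percentage points lower from compound 2 to compound 3 (within the scatter)), so this position, on the side of the core where compound 2 and compound 3 differ, shows no readable response to this change. Among the compounds shown here, compound 3 also provides the first comparison in one place on the other aryl ring, with phenyl held constant on the thiazole side: the step from 3,4-dimethoxyphenyl to 4-chlorophenyl is modest but readable (a number 10.1 percentage points higher from compound 1 to compound 3 (beyond the scatter)), and the lower number belongs to the 3,4-dimethoxyphenyl compound. No measurement here bears on the reason for either step.

A single methoxy group, a dimethylamino group or a carboxylic acid on that ring would help show whether the step belongs to the methoxy groups or to the loss of chloro. It also remains open whether the same step holds with 4-chlorophenyl rather than phenyl on the thiazole side, and how any of these compounds behaves at concentrations other than the one tested.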